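Same side-chain swap on a different chain length

The source may report more compounds than this note shows. Statements on the series, on what has been measured and on what is new or still open speak of the compounds shown alone.

Three compounds were measured in a functional assay on the whole organism (Tail, strain ICR) with Mus musculus as the target, in the tail flick test, with a stated time of 60 min, at a dose of 25 umol/kg by the oral route; a higher number here means a stronger effect of the compound at the dose given, a lower number a weaker effect. Compound 1 `NC(=O)C[C@H](NC(=O)CN(c1nc(Cl)nc2[nH]cnc12)C1CC1)C(=O)O` gives 43.1%, and compound 2 `CC(C)[C@H](NC(=O)CN(c1nc(Cl)nc2[nH]cnc12)C1CC1)C(=O)O` gives 38.8%. Between them the change is isopropyl in place of carbamoylmethyl on a saturated chain carbon bound to an amide-type nitrogen and a carbonyl carbon, and the step was a number 4.3 percentage points lower from compound 1 to compound 2 (within the scatter). Compound 3 `NC(=O)CC[C@H](NC(=O)CN(c1nc(Cl)nc2[nH]cnc12)C1CC1)C(=O)OCc1ccccc1` gives 33.1% in this assay; how its core differs from that of compound 1 is not broken down here. Compound 4 `CC(C)C[C@H](NC(=O)CN(c1nc(Cl)nc2[nH]cnc12)C1CC1)C(=O)OCc1ccccc1` carries the change (isopropyl in place of carbamoylmethyl on a saturated chain carbon, two bonds along the chain from an amide-type nitrogen and a carbonyl carbon). This is the same kind of change as from compound 1 to compound 2, but the place is not identical: here the carbon sits two bonds along the chain from the amide-type nitrogen and carbonyl carbon, not directly bound to them. Because the earlier step was a number 4.3 percentage points lower from compound 1 to compound 2 (within the scatter), a similarly small step is expected here, a number 4.1 percentage points lower from compound 3 to compound 4 (within the scatter). Compound 4 is therefore estimated at 29%, with a likely range from 15% to 44%.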

Compound 4, a percentage reported as activity, at one dose (the size of the read-out at that dose, not a potency): 27.3%
Beside the measured number, compound 4's estimate is 1.7 percentage points above it; the range from low to high includes it.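

In this assay, putting isopropyl in place of carbamoylmethyl gives a number 5.8 percentage points lower from compound 3 to compound 4 (within the scatter), and this matches the earlier step on the other core: the same change on two cores in this assay, a number 4.3 percentage points lower (within the scatter) from compound 1 to compound 2 and a number 5.8 percentage points lower (within the scatter) from compound 3 to compound 4, 1.5 percentage points apart, within the scatter of two such steps So across these two cores the change behaves alike, with a small step each time. This does not show that the change really lowers the effect, as neither step rises above the scatter, and it says nothing about other cores, especially as the changed carbon does not sit in quite the same place in the two pairs.

Still open, on these data alone, is how a primary amine or a hydroxyl group would compare with isopropyl on this side chain. A longer straight carbon chain there is also left open.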